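The compounds below may be only part of what the source reports. "The series", "measured", "known", "first", "only" and "open" are said of these compounds alone.

For the measured compounds named here, in a functional assay on HepG2 cells (Homo sapiens) for inhibition, read by MTT assay (a higher number here means a weaker inhibitor, a lower number a stronger inhibitor), three amides on a shared core have numbers so far: compound 1 `COc1cc2ncnc(Nc3ccc(NC(=O)c4ccccc4F)cc3)c2cc1OC` gives 13000 nM, compound 2 `COc1cc2ncnc(Nc3ccc(NC(=O)c4ccccc4Cl)cc3)c2cc1OC` gives 26000 nM, and compound 3 `COc1cc2ncnc(Nc3ccc(NC(=O)c4ccccc4I)cc3)c2cc1OC` gives 33000 nM. The standing of the last of these is told by two steps: a 1.3-fold higher number from compound 2 to compound 3 (0.10 log units; within the scatter), and a 2.5-fold higher number from compound 1 to compound 3 (0.40 log units; beyond the scatter). Compound 4 `COc1cc2ncnc(Nc3ccc(NC(=O)c4c(F)cccc4F)cc3)c2cc1OC` has 2,6-difluorophenyl in place of 2-iodophenyl on a carbonyl carbon. Going by the values given here, the closest measured guide is the fluoro compound, compound 1 at 13000 nM, although no measured compound carries two fluoro groups. A modest move to a lower number is therefore expected in this assay, an estimated 2.2-fold lower number from compound 3 to compound 4 (0.34 log units; beyond the scatter). Compound 4 is expected at 15000 nM, with an estimated range of 6000 nM to 35000 nM.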

Compound 4, half-maximal inhibitory concentration: 17000 nM
For compound 4 the middle estimate is 1.1-fold (0.05 log units) below the measured one; the measured number falls inside the stated range.
By their numbers in this assay, from the lowest: compounds 1, 4, 2 and 3 (each within the scatter of the next, the first and the last beyond it).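

Adding a second fluoro to the ring of compound 1 leaves the number in this assay within the scatter, with (a 1.3-fold higher number from compound 1 to compound 4 (0.12 log units; within the scatter)). The same holds against the other two halogen compounds, with (a 1.5-fold lower number from compound 2 to compound 4 (0.18 log units; within the scatter)) and (a 1.9-fold lower number from compound 3 to compound 4 (0.29 log units; within the scatter)), so 2,6-difluorophenyl cannot be told apart from 2-chlorophenyl or 2-iodophenyl here. Nothing measured here offers a reason for these numbers.

Going by these compounds, every group on this carbonyl carbon so far is a halogen-bearing phenyl, so what an unsubstituted phenyl, a methoxy group or an amine on that ring would do stays open.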